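This account rests on a few compounds, and the source may have more. Where it says the series, first, only, none or still open, it means among the compounds named here.

Working notes on the series. In an ADME assay on NCM460 cells (Homo sapiens) for cytotoxicity, read by MTT assay, with a stated time of 24 h (on this read-out higher numbers stand for lower toxicity in this test and lower numbers for higher toxicity in this test), compound 3 `CC1(C)[C@H]2CC[C@]1(C)N(Cc1cn(-c3ccccc3Cl)nn1)C(=O)C2` gives 10800 nM and sits within the scatter of compound 1 `CC1(C)[C@H]2CC[C@]1(C)N(Cc1cn(-c3ccc(C#N)cc3)nn1)C(=O)C2` at 8140 nM with a 1.3-fold higher number from compound 1 to compound 3 (0.12 log units; within the scatter) as the step between them. Compound 3 stands clear of compound 2 `CC1(C)[C@H]2CC[C@]1(C)N(Cc1cn(-c3ccccc3F)nn1)C(=O)C2` at 5260 nM with a 2.1-fold higher number from compound 2 to compound 3 (0.31 log units; beyond the scatter) as a modest step. Next comes compound 4 `CC1(C)[C@H]2CC[C@]1(C)N(Cc1cn(-c3ccccc3)nn1)C(=O)C2` with the change hydrogen in place of chloro on an aromatic carbon that turns 2-chlorophenyl to phenyl. For the measured compounds named here, no measured compound carries a plain phenyl, so the step has no direct precedent. The closest measured change is chloro in place of fluoro on an aromatic carbon, seen in a 2.1-fold higher number from compound 2 to compound 3 (0.31 log units; beyond the scatter) and only just beyond the scatter. The swaps away from 4-cyanophenyl, a 1.5-fold lower number from compound 1 to compound 2 (0.19 log units; within the scatter) and a 1.3-fold higher number from compound 1 to compound 3 (0.12 log units; within the scatter), both stay within it. Across these three compounds the aryl group moves the number little, so no step beyond the scatter is expected. The estimated step is a 1.4-fold lower number from compound 3 to compound 4 (0.13 log units; within the scatter) and it leans slightly downward. For compound 4 the estimate is 8000 nM with an expected range of 4000 nM to 16000 nM in this assay as the working figure.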

Compound 4, half-maximal cytotoxic concentration: 19600 nM
Estimate against measurement, compound 4: 2.5-fold (0.39 log units) below; the whole stated range lies below it.
By their numbers in this assay, from the lowest: compounds 2, 1, 3 and 4 (each within the scatter of the next, the first and the last beyond it).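

In this assay, hydrogen in place of chloro on an aromatic carbon gives a 1.8-fold higher number from compound 3 to compound 4 (0.26 log units; within the scatter), so at this place, ortho to a large group, the chloro can be dropped without a step beyond the scatter. Hydrogen in place of fluoro gives a 3.7-fold higher number from compound 2 to compound 4 (0.57 log units; beyond the scatter) and hydrogen in place of cyano gives a 2.4-fold higher number from compound 1 to compound 4 (0.38 log units; beyond the scatter), so the plain phenyl of compound 4 stands clear of compound 2 and compound 1, though not of compound 3, and both steps are modest. Nothing available explains why these steps differ in size.

Going by these compounds, whether an amine or a carboxylic acid on the phenyl ring would stay within the scatter of compound 4 remains open. Also open, on these data alone, is how a cyclohexyl group in place of the phenyl would read on the shared core.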